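The compounds below may be only part of what the source reports. "The series", "measured", "known", "first", "only" and "open" are said of these compounds alone.

Of the compounds shown here, three sharing one core have been tested in an ADME assay on NIH3T3 cells (Mus musculus) for cytotoxicity, read by MTT assay, with a stated time of 24 h; a lower number here means a stronger inhibitor, a higher number a weaker inhibitor. Compound 1 `O=C(CSc1nnc(-c2ccncc2)o1)N/N=C/c1ccc(F)cc1` gives 170000 nM in this assay, the highest of the three numbers, though its distance to the other two lies within the scatter. Compound 2 `O=C(CSc1nnc(-c2ccncc2)o1)N/N=C/c1ccc(Br)cc1` gives 169000 nM, and compound 3 `O=C(CSc1nnc(-c2ccncc2)o1)N/N=C/c1ccc(O)c(O)c1` gives 154000 nM. The step of a 1.0-fold lower number from compound 1 to compound 2 (0.00 log units; within the scatter) and the step of a 1.1-fold lower number from compound 1 to compound 3 (0.04 log units; within the scatter) show that swapping the aryl group at the carbon with a double bond to nitrogen, whether for a bromo in place of fluoro or a 3,4-dihydroxyphenyl in place of 4-fluorophenyl, has left the number essentially unchanged.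

Compound 4 `O=C(CSc1nnc(-c2ccncc2)o1)N/N=C/c1cccs1` is not yet measured. It differs from compound 1 in one place: thiophen-2-yl in place of 4-fluorophenyl on a carbon with a double bond to nitrogen. Both measured steps at this same position were flat, so no step beyond the scatter is expected from compound 1 to compound 4 in this assay, and the expected step is a 1.1-fold lower number from compound 1 to compound 4 (0.03 log units; within the scatter). Compound 4 is therefore estimated at 160000 nM, with a likely range from 80000 nM to 320000 nM.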

Compound 4, half-maximal inhibitory concentration: 189000 nM
Estimate against measurement, compound 4: 1.2-fold (0.07 log units) below, within the range that was stated.
By their numbers in this assay, from the lowest: compounds 3, 2, 1 and 4 (each within the scatter of the next).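

In this assay, the position on a carbon with a double bond to nitrogen stays flat even when the ring itself changes, not only what it carries: with thiophen-2-yl the result is a 1.1-fold higher number from compound 1 to compound 4 (0.05 log units; within the scatter) and also a 1.1-fold higher number from compound 2 to compound 4 (0.05 log units; within the scatter) and a 1.2-fold higher number from compound 3 to compound 4 (0.09 log units; within the scatter) at this position. Replacing a six-membered aromatic ring of carbon only with a five-membered aromatic ring with 1 hetero atom therefore moves the number no further than the substituent swaps did. No measurement shown explains this flat result.

On these data alone, all four groups at this position are aromatic rings, so it remains open whether an amine, a carboxylic acid or a longer alkyl chain there would leave the number equally flat. Changes elsewhere in the shared core also remain open.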